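Fluoro to Chloro Swaps in an Isatin Thiosemicarbazone Series

The source may report more compounds than this note shows. Statements on the series, on what has been measured and on what is new or still open speak of the compounds shown alone.

The measured compounds:
compound 1, `O=C1Nc2ccc(Cl)cc2/C1=N/NC(=S)Nc1ccc(Cl)cc1`, 64000 nM
compound 2, `O=C1Nc2ccc(F)cc2/C1=N/NC(=S)Nc1ccc(Cl)cc1`, 14000 nM
compound 3, `Cc1ccc(NC(=S)N/N=C2\C(=O)N(Cc3ccc(F)cc3)c3ccc(Br)cc32)cc1`, 57000 nM

All three were tested in a functional assay on MOLT-4 cells (Homo sapiens), with a stated time of 72 h; on this read-out higher numbers stand for weaker inhibition and lower numbers for stronger inhibition. In this assay compound 2 gives 14000 nM, and compound 1 gives 64000 nM. The two differ by chloro in place of fluoro on an aromatic carbon; the step is a 4.6-fold higher number from compound 2 to compound 1 (0.66 log units; beyond the scatter). Compound 3 gives 57000 nM in this assay. Its structure carries a different core from that of compound 2, and the difference between the two cores is not broken down here; the two values simply show that compound 3 sits with the higher number, far from compound 2 but close to compound 1.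

Compound 4, `Cc1ccc(NC(=S)N/N=C2\C(=O)N(Cc3ccc(Cl)cc3)c3ccc(Br)cc32)cc1`, has not yet been measured. It differs from compound 3 by chloro in place of fluoro on an aromatic carbon. This is the same kind of change as that from compound 2 to compound 1, not the same: in compound 1 the chloro sits on a ring that is part of a fused or bridged system of two rings, meta to a fused ring and para to a fused ring, whereas in compound 4 it sits on a six-membered aromatic ring of carbon only, para to a large group. Among the measured compounds shown here, because a 4.6-fold higher number from compound 2 to compound 1 (0.66 log units; beyond the scatter) is the only measured precedent, and it stands on a different ring, the step expected here is a 1.3-fold higher number from compound 3 to compound 4 (0.12 log units; within the scatter), smaller than the earlier one and carried by wide uncertainty. Compound 4 is therefore estimated at 75000 nM, between 30000 nM and 200000 nM.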

Compound 4, half-maximal inhibitory concentration: 288000 nM
Compound 4: the middle estimate sits 3.8-fold (0.58 log units) below what was measured, and the stated range ends below it.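

In this assay, exchanging fluoro for chloro on the benzyl group, so that 4-fluorobenzyl becomes 4-chlorobenzyl, gives a 5.1-fold higher number from compound 3 to compound 4 (0.70 log units; beyond the scatter), so inhibition weakens on this core as it did on the core of compound 1. Set side by side, the two steps agree in direction and in size: the same change on two cores in this assay, a 4.6-fold higher number (0.66 log units; beyond the scatter) from compound 2 to compound 1 and a 5.1-fold higher number (0.70 log units; beyond the scatter) from compound 3 to compound 4, 1.1-fold (0.04 log units) apart, within the scatter of two such steps. This shows that the change carried across these two cores with much the same result, even though the halogen stands on a different ring in each pair, but it does not show why the two steps match, and two pairs are too few to make a rule for the whole series.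

The compounds shown leave open whether a group such as methoxy or an amine, placed on that same aromatic carbon of the benzyl ring, would give a number closer to the fluoro compound 3 or to the chloro compound 4. They also leave open whether the fluoro to chloro step would keep its size on a core with a longer chain in place of the benzyl group, or in a cell line other than this one.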